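A few compounds are considered here, and "the series" means these few. Any claim that something is new, unique, unknown or untested is made for them only; others in the source may bear on it.

Measured compounds:
Compound 1 `O=C(CSc1snnc1-c1ccc(Br)cc1Br)Nc1ccccn1` gives 42400 nM in an ADME assay on MT4 cells (Homo sapiens) for cytotoxicity, read by MTT assay, with a stated time of 5 days; on this read-out higher numbers stand for lower toxicity in this test and lower numbers for higher toxicity in this test.
Compound 2 `Cc1ccc(NC(=O)CSc2snnc2-c2ccc(Br)cc2Br)c([N+](=O)[O-])c1` gives > 229000 nM in this assay, which is a limit of the assay and not a number.
Compound 3 `Cc1cccc(C)c1NC(=O)CSc1snnc1-c1ccc(Br)cc1Br` gives >= 198000 nM in this assay, which is likewise only a limit.

Among the values shown, compound 3 is therefore known only as a limit (the limit of >= 198000 nM in this assay, at which 1 of the 3 values shown sits). Compound 4 `O=C(CSc1snnc1-c1ccc(Br)cc1Br)Nc1ccccc1` differs from compound 3 by phenyl in place of 2,6-dimethylphenyl on an amide-type nitrogen. Within the data shown here, the single measured step, an at least 4.6-fold higher number from compound 1 to compound 3 (0.66 log units; beyond the scatter), concerns a different exchange on the same nitrogen, so no measured step bears directly on the present change. Compound 4 is accordingly expected to sit near compound 3, with the step of an at least 1.3-fold lower number from compound 3 to compound 4 (0.12 log units; that floor lies within the scatter) estimated as small and probably within the scatter. The estimate for compound 4 is 150000 nM, ranging from 50000 nM to 250000 nM, with a fair chance that only a limit is reported again.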

Compound 4, half-maximal cytotoxic concentration: 24800 nM
Compound 4: middle estimate off by 6.0-fold (0.78 log units), on the high side, and the stated range ends above it.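

With phenyl in place of 2,6-dimethylphenyl on the amide-type nitrogen, this assay shows an at least 7.9-fold lower number from compound 3 to compound 4 (0.90 log units; beyond the scatter), so this exchange is not silent at this position. Phenyl and pyridin-2-yl on the same nitrogen are not separated, with a 1.7-fold lower number from compound 1 to compound 4 (0.23 log units; within the scatter). The first step is only a floor, since compound 3 is known only as a limit: the limit of >= 198000 nM in this assay, at which 1 of the 4 values shown sits.

On these data alone, whether a single methyl group on the phenyl would be enough remains open. Also open, as far as these compounds go, is how a phenyl carrying an amine or a carboxylic acid would read in this assay.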